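The source may hold more compounds than are shown below. What is called first, only, known or untested is meant among the compounds shown, and "the series" means these compounds.

In a functional assay on SK-N-SH cells (Homo sapiens) for cytotoxicity, read by MTT assay, with a stated time of 24 h (a lower number here means a stronger inhibitor, a higher number a weaker inhibitor), compound 1 `C/C(=N\NC(=O)/C(C#N)=C/c1ccc(O)cc1)c1c(O)c2ccc(O)cc2oc1=O` gives 8120 nM and compound 2 `COc1ccc(/C=C(\C#N)C(=O)N/N=C(\C)c2c(O)c3ccc(O)cc3oc2=O)cc1` gives 9460 nM, so compound 2 stands level with compound 1 within the usual scatter. Compound 3 `C/C(=N\NC(=O)/C(C#N)=C/c1ccc(Br)cc1)c1c(O)c2ccc(O)cc2oc1=O` has bromo in place of methoxy on an aromatic carbon, para to a large group: bromo in place of methoxy on an aromatic carbon. For the measured compounds named here, the only measured step at this group, a 1.2-fold higher number from compound 1 to compound 2 (0.07 log units; within the scatter), stayed within the scatter. Going by the values given here, no measured compound carries bromo, so this is thin evidence, and no change beyond the scatter is expected in this assay. The expected step is a 1.2-fold lower number from compound 2 to compound 3 (0.07 log units; within the scatter). For compound 3 the estimate is 8000 nM, with an expected range of 3500 nM to 18000 nM.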

Compound 3, half-maximal inhibitory concentration: 12100 nM
The estimate for compound 3 lay 1.5-fold (0.18 log units) below the measured number; the range from low to high includes it.
By their numbers in this assay, from the lowest: compounds 1, 2 and 3 (each within the scatter of the next).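

With bromo, a third group has now been read on this aromatic carbon in this assay: a 1.3-fold higher number from compound 2 to compound 3 (0.11 log units; within the scatter), and a 1.5-fold higher number from compound 1 to compound 3 (0.17 log units; within the scatter). Both steps stay within the scatter, so hydroxy, methoxy and bromo at this place cannot be told apart in this assay. No other measurement bears on this result. From the compounds shown here alone, whether an amine, a carboxylic acid or a longer chain here would give a step beyond the scatter remains open, as does the effect of changes elsewhere on the shared core.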